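Swapping the Urea Aryl Group: From Isoquinoline to Indazole

The source may report more compounds than this note shows. Statements on the series, on what has been measured and on what is new or still open speak of the compounds shown alone.

The measured compounds so far:

Compound 1, `O=C(NCc1ccc(N2CCCCCC2)cc1C(F)(F)F)Nc1cccc2cnccc12`: in a functional assay for antagonist activity at transient receptor potential cation channel subfamily V member 1 (Homo sapiens), read by calcium flux (a lower number here means a stronger inhibitor, a higher number a weaker inhibitor), compound 1 gives 5.7 nM.
Compound 2, `O=C(NCc1ccc(N2CCCCCC2)c(C(F)(F)F)c1)Nc1cccc2cnccc12`: in this assay compound 2 gives 4.6 nM.
Compound 3, `O=C(NCc1ccc(N2CCCCCC2)cc1C(F)(F)F)Nc1cccc2[nH]ncc12`: in this assay compound 3 gives 133 nM.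

All three share a urea linker carrying, on one side, a benzylic arm that bears an azepane ring and a trifluoromethyl group, and on the other side an aromatic bicycle. Compound 1 and compound 2 are built from the same atoms joined differently; the difference between the two cores is not broken down here. Their values in this assay lie within the usual scatter of each other, so no order between them can be drawn.

Compound 3 is compound 1 with one change: 1H-indazol-4-yl in place of isoquinolin-5-yl on an amide-type nitrogen. This produced a 23-fold higher number from compound 1 to compound 3 (1.37 log units; beyond the scatter), a clear loss of inhibitory strength.

Compound 4, `O=C(NCc1ccc(N2CCCCCC2)c(C(F)(F)F)c1)Nc1cccc2[nH]ncc12`, is the still unmeasured partner of compound 2. It differs from compound 2 in the same way: 1H-indazol-4-yl in place of isoquinolin-5-yl on an amide-type nitrogen. The place is identical in both pairs, an amide-type nitrogen next to the carbonyl carbon, so this is the same change made on a core that performs almost the same as that of compound 1. Going by the values given here, the expectation is therefore a step of roughly the same size as the one from compound 1 to compound 3, estimated as a 23-fold higher number from compound 2 to compound 4 (1.36 log units; beyond the scatter), because of a 23-fold higher number from compound 1 to compound 3 (1.37 log units; beyond the scatter). On that basis compound 4 is expected to give about 105 nM in this assay, most likely between 40 nM and 300 nM.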

Compound 4, half-maximal inhibitory concentration: 29.5 nM
Compound 4: the middle estimate sits 3.6-fold (0.55 log units) above what was measured; the whole stated range lies above it.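

Putting 1H-indazol-4-yl in place of isoquinolin-5-yl on the amide-type nitrogen again weakens inhibition in this assay, with a 6.4-fold higher number from compound 2 to compound 4 (0.81 log units; beyond the scatter), so the direction of the change carries over from the core of compound 1 to the core of compound 2. The size of the change does not carry over, and the two steps differ by more than the usual scatter would explain: the same change on two cores in this assay, a 23-fold higher number (1.37 log units; beyond the scatter) from compound 1 to compound 3 and a 6.4-fold higher number (0.81 log units; beyond the scatter) from compound 2 to compound 4, 3.6-fold (0.56 log units) apart, beyond the scatter of two such steps

With 1H-indazol-4-yl attached, compound 3 gives 133 nM and compound 4 gives 29.5 nM, but two pairs cannot show why the loss is smaller on one core, nor how the same change would behave on any further core.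

Still open, on these data alone, is which difference between the two aryl groups drives the loss, for instance whether the hydrogen-bond donor that enters with 1H-indazol-4-yl plays any part, a question that a group such as 1H-indol-4-yl or quinolin-5-yl on the same nitrogen could help to answer. As far as these compounds go, it is also open whether the step would keep its size if a piperidine took the place of the azepane ring on either core.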